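A few compounds are considered here, and "the series" means these few. Any claim that something is new, unique, unknown or untested is made for them only; others in the source may bear on it.

Series notes. Among the compounds with values here, compound 1 `CC(C)CN1CCc2c(sc(NC(=O)Nc3ccc(Cl)cc3)c2C(N)=O)C1` is the only member with a numerical result in a functional assay (strain AB) with Danio rerio as the target, read by microscopy, with a stated time of 1 h; a lower number here means that less compound is needed, a higher number that more compound is needed for the effect: compound 1 gives 4510 nM. Compound 2 `CCN1CCc2c(sc(NC(=O)Nc3ccc(Cl)cc3)c2C(=O)NC)C1` reaches only the limit of this assay, > 25000 nM, so no number is known for it. The set therefore sits at the limit of > 25000 nM in this assay, at which 1 of the 2 values shown sits, for one of its two values. Compound 3 `CC(C)(C)OC(=O)N1CCc2c(sc(NC(=O)Nc3ccc(Cl)cc3)c2C(N)=O)C1` differs from compound 1 by tert-butoxycarbonyl in place of isobutyl on an amine nitrogen in a ring. Within the data shown here, no measured pair in the set covers this change, so the direction is open; a step somewhat beyond the scatter, toward more compound being needed, is expected, giving a 2.0-fold higher number from compound 1 to compound 3 (0.30 log units; within the scatter). For compound 3 the estimate in this assay is 9000 nM, ranging from 2500 nM to 25000 nM.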

Compound 3, half-maximal effective concentration: > 25000 nM
Compound 3 gave a limit, no number; the forecaster's own chance of this, stated with the estimate: 30%; at least 2.7-fold (0.44 log units) between middle value and limit.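

In this assay, within the data shown here, tert-butoxycarbonyl in place of isobutyl on the amine nitrogen in the ring gives the first readable step: an at least 5.5-fold higher number from compound 1 to compound 3 (0.74 log units; beyond the scatter). Going by these compounds, the position is therefore not indifferent to its substituent, though the step's true size remains unknown, as compound 3 gave a limit and not a number. Compound 1 remains the only member with a numerical result: the limit of > 25000 nM in this assay, at which 2 of the 3 values shown sit.

Open, on these data alone, is whether a free amine, an acetyl or a benzyl on this nitrogen would give a numerical result. Also open, as far as these compounds go, is whether the carbonyl or the overall size of the entering group drives the step.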